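A few compounds are considered here, and "the series" means these few. Any claim that something is new, unique, unknown or untested is made for them only; others in the source may bear on it.

Measured so far:
- compound 1 `CC[C@@H]1CCC[C@H](C(=O)O)O1`: 14.1%
- compound 2 `CC(C)C(=O)OC[C@H]1C[C@@H](Cl)C[C@@H](c2cccc3ccccc23)O1`: 38.4%

Both numbers come from a functional assay on the whole organism (Abdomen, strain Swiss albino) for inhibition, with Mus musculus as the target, in the writhing test, with a stated time of 30 min, at a dose of 30 mg/kg by the oral route; a lower number here means less inhibition, a higher number more inhibition at the dose given (going by the name of the read-out). Of the two, compound 2 gives the higher reading; compound 1 lies below it by a gap beyond the usual scatter, so compound 2 stands highest among the measured compounds.

The next compound, compound 3 `O=C(O)[C@H]1C[C@@H](Cl)C[C@@H](c2cccc3ccccc23)O1`, differs from compound 2 in one place: carboxy in place of ((isopropylcarbonyl)oxy)methyl on a saturated ring carbon. The larger ester-bearing group is thus replaced by the smaller carboxy group.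

Within the data shown here, no measured pair with a single change is available to say how large such a step should be. Compound 1, which also carries a carboxy group, gives 14.1% in this assay, though it shares no other feature with compound 3. On that thin basis, a modest move downward is expected, from compound 2 to compound 3 of a number 10.4 percentage points lower from compound 2 to compound 3 (beyond the scatter). Compound 3 is expected to give about 28%, with a range from 10% to 48%.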

Compound 3, a percentage reported as inhibition, in the whole organism at one dose (the size of the read-out at that dose, not a potency): 54.4%
Compound 3: middle estimate off by 26.4 percentage points, on the low side; measured number above the stated range.
By their numbers in this assay, from the lowest: compound 1; then compound 2; then compound 3.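

Replacing ((isopropylcarbonyl)oxy)methyl with carboxy on this saturated ring carbon next to the ring oxygen gives a number 16 percentage points higher from compound 2 to compound 3 (beyond the scatter) in this assay at the single dose tested. Among these compounds, this is the first step that changes only one place, and it shows that the larger ester-bearing group is not needed to keep this reading, since the smaller carboxy group raises it. Nothing measured here explains the rise.

On these data alone, it remains open whether the gain belongs to the carboxy group itself or simply follows from losing the larger group, and a methyl ester or a primary amide on this ring carbon would help separate those two readings. A single dose also leaves open whether the same order would hold at other doses.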